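Same Chlorophenyl Exchange Applied to a Second Core

The source may report more compounds than this note shows. Statements on the series, on what has been measured and on what is new or still open speak of the compounds shown alone.

Three compounds were measured in a functional assay on the whole organism (artery, strain albino) with Rattus norvegicus as the target, with a stated time of 60 min, at a dose of 10 mg/kg by the oral route; on this read-out lower numbers stand for less inhibition and higher numbers for more inhibition at the one dose given (going by the name of the read-out). Compound 1 `COc1ccc(C2N=C(SCc3cccc(Cl)c3)NC(C)=C2C(=O)Nc2ccc(F)cc2)cc1OC` gives 8.2% in this assay. Compound 2 `COc1ccc(C2N=C(SCc3ccc(Cl)cc3)NC(C)=C2C(=O)Nc2ccc(F)cc2)cc1OC` gives 10.3%. Compound 3 `CC1=C(C(=O)Nc2ccc(Br)cc2)C(c2ccc(Cl)cc2Cl)N=C(SCc2cccc(Cl)c2)N1`, which carries a different core, gives 6.2%; the difference between the core of compound 3 and the core of compound 1 is not broken down here. All three numbers lie within the usual scatter of one another, so no ordering among them is claimed.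

Compounds 1 and 2 differ in one place: 4-chlorophenyl in place of 3-chlorophenyl on a saturated chain carbon bound to a sulfur. The measured step is a number 2.1 percentage points higher from compound 1 to compound 2 (within the scatter).

Compound 4 `CC1=C(C(=O)Nc2ccc(Br)cc2)C(c2ccc(Cl)cc2Cl)N=C(SCc2ccc(Cl)cc2)N1` has not yet been measured. It stands to compound 3 exactly as compound 2 stands to compound 1, by the same change: 4-chlorophenyl in place of 3-chlorophenyl on a saturated chain carbon bound to a sulfur. The place line is the same word for word in both pairs, so the change is the same, made once on each core.

Going by the values given here, because the only measured instance of this change, a number 2.1 percentage points higher from compound 1 to compound 2 (within the scatter), lies within the scatter, compound 4 is expected to sit close to compound 3. The step from compound 3 to compound 4 is estimated at a number 1.8 percentage points higher from compound 3 to compound 4 (within the scatter) in this assay. This rests on a single measured pair, on a different core, so the expectation carries wide uncertainty. Compound 4 is therefore estimated to give 8% in this assay, with a likely range from 0% to 20%.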

Compound 4, a percentage reported as inhibition, in the whole organism at one dose (the size of the read-out at that dose, not a potency): 11.8%
Compound 4: the middle estimate sits 3.8 percentage points below what was measured; low and high end bracket the measured number.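

In this assay, putting 4-chlorophenyl in place of 3-chlorophenyl on a saturated chain carbon bound to a sulfur gives a number 5.6 percentage points higher from compound 3 to compound 4 (within the scatter), so on this second core too the step stays inside the usual scatter. Set beside each other, the two instances of the change cannot be told apart: the same change on two cores in this assay, a number 2.1 percentage points higher (within the scatter) from compound 1 to compound 2 and a number 5.6 percentage points higher (within the scatter) from compound 3 to compound 4, 3.5 percentage points apart, within the scatter of two such steps What this shows is that nothing in these four compounds separates the behaviour of the change on one core from its behaviour on the other; what it does not show is that the change has a real effect on either core, or that a step of a fixed size carries over, as neither step stands clear of the scatter and only two cores at one oral dose are covered.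

The compounds shown carry only a chlorophenyl group on the chain carbon bound to the sulfur, which leaves open how a longer chain, an amine or a carboxylic acid at that place would read in this assay. Also open, going by these compounds, is whether the exchange of 3-chlorophenyl for 4-chlorophenyl would read the same on a third core or at another dose.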